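The source may report more compounds than this note shows. Statements on the series, on what has been measured and on what is new or still open speak of the compounds shown alone.

Compound 1 `CCC(C)(C)Cc1c[nH]c(CCc2ccc(-n3cccn3)cc2)n1` gives 135 nM in a functional assay on HEK293 cells for agonist activity at Bombesin receptor subtype-3 (Homo sapiens), read by luminescence and calcium flux, with a stated time of 10 min; a lower number here means that less compound is needed, a higher number that more compound is needed for the effect. Compound 2 `CCC(C)(C)Cc1c[nH]c(CCc2ccc(-c3ccc(F)cn3)cc2)n1` gives 66 nM in this assay. Compound 3 `c1ccc(-c2ccc(CCc3nc(CC4CCCC4)c[nH]3)cc2)nc1` gives 425 nM in this assay.

Among these three, compound 2 stands at the lowest number: compound 1 is the nearest to it, and compound 3 the furthest. For the measured compounds named here, the one single-change step among them, a 2.0-fold lower number from compound 1 to compound 2 (0.31 log units; beyond the scatter), swaps one aromatic group for another at the end of the shared core and moves the number by a modest amount.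

Compound 4 `CCC(C)(C)Cc1c[nH]c(CCc2ccc(N3CCCCC3)cc2)n1` is the next compound in this series. It differs from compound 2 in one place: piperidin-1-yl in place of 5-fluoropyridin-2-yl on an aromatic carbon. This is a change of a different kind from the one already measured. Here the aromatic ring is replaced by a non-aromatic ring bearing a nitrogen that joins directly to the shared core. Going by the values given here, no measured step covers such a swap, so the only guide is that the step from compound 1 to compound 2 stayed modest, and that compound 3, which keeps an aromatic group, gives the highest number seen. Given this, the expectation for compound 4 is a somewhat higher number than compound 2, with wide uncertainty: an estimated 3.0-fold higher number from compound 2 to compound 4 (0.48 log units; beyond the scatter), meaning compound 4 is expected near 200 nM, between 60 nM and 700 nM.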

Compound 4, half-maximal effective concentration: 171 nM
Beside the measured number, compound 4's estimate is 1.2-fold (0.07 log units) above it, and the stated range covers the measured number.
By their numbers in this assay, from the lowest: compound 2; then compounds 1 and 4 (each within the scatter of the next); then compound 3.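

In this assay, the place on an aromatic carbon para to a large group accepts a non-aromatic ring: the change from 5-fluoropyridin-2-yl to piperidin-1-yl gives a 2.6-fold higher number from compound 2 to compound 4 (0.41 log units; beyond the scatter) and is a modest step. The comparison with the other aromatic group is less clear-cut, as the change from 1H-pyrazol-1-yl to piperidin-1-yl gives a 1.3-fold higher number from compound 1 to compound 4 (0.10 log units; within the scatter), so these two groups cannot be told apart here even though only one of them is aromatic. Whether the ring is aromatic therefore does not by itself set the number among these three compounds, and nothing available explains why 5-fluoropyridin-2-yl stands apart from the other two groups.

From the compounds shown here alone, it remains open whether the ring nitrogen that joins piperidin-1-yl to the shared core matters, which a cyclohexyl group, with carbon in its place, could test, while morpholin-4-yl could show how a ring oxygen fits at this place. The part played by the fluorine is also unsettled, and a pyridin-2-yl group without it, on the same 2,2-dimethylbutyl-bearing structure, would separate that atom from its ring.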